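The source may hold more compounds than are shown below. What is called first, only, known or untested is meant among the compounds shown, and "the series" means these compounds.

Measured compounds:
Compound 1, `Nc1nc(NCc2ccccc2)nc(-c2ccc(Cl)cc2CO)n1`; in a functional assay on cells for positive allosteric modulation of G-protein coupled receptor 68 (Homo sapiens), read by a luciferase reporter and cAMP accumulation, with a stated time of 30 min, at pH 6.8 and pH 8.3, in the presence of a further agent that is not named here (on this read-out lower numbers stand for lower potency and higher numbers for higher potency (the scale is a negative logarithm)), compound 1 gives 4.76.
Compound 2, `CCOc1ccc(-c2nc(N)nc(NCc3ccccc3)n2)c(CO)c1`; in this assay compound 2 gives 4.37.
Compound 3, `Nc1nc(NCc2cccc(F)c2)nc(-c2ccccc2CO)n1`; in this assay compound 3 gives 4.52.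

Compound 3 cannot be told apart from either neighbour: its number lies within the usual scatter of that of compound 1 and of that of compound 2. Among the compounds with values here, the one step that goes beyond the scatter, a number 0.39 log units lower from compound 1 to compound 2 (beyond the scatter), concerns the aryl ring bearing the hydroxymethyl group and not the benzyl part of the shared core.

Compound 4, `Cc1ccc(CNc2nc(N)nc(-c3ccccc3CO)n2)cc1`, differs from compound 3 by 4-methylphenyl in place of 3-fluorophenyl on a saturated chain carbon bound to a nitrogen on an aromatic ring. Within the data shown here, no measured pair shows a change at this place, so none of the steps seen bears directly on it, and the three numbers together span a narrow band. On that basis compound 4 is expected to land close to compound 3, with a number 0.02 log units lower from compound 3 to compound 4 (within the scatter) expected to stay within the scatter. Compound 4 is therefore estimated at 4.5 in this assay, with a range from 4 to 5.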

Compound 4, negative logarithm of the antagonist equilibrium constant: 4.38
The estimate for compound 4 lay 0.12 log units above the measured number, and the stated range covers the measured number.
By their numbers in this assay, from the lowest: compounds 2, 4, 3 and 1 (each within the scatter of the next, the first and the last beyond it).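

In this assay, within the data shown here, 4-methylphenyl in place of 3-fluorophenyl gives a number 0.14 log units lower from compound 3 to compound 4 (within the scatter), the first reading of a change on the saturated chain carbon bound to a nitrogen on an aromatic ring. This single swap alters both the substituent and its place on the phenyl ring, yet it does not separate the two compounds, and it cannot show whether either alteration alone would matter. Nothing available here offers an explanation for how close these two numbers lie.

The compounds shown leave open how an amine, a carboxylic acid or a pyridine ring would read at this place, and whether a longer chain would move the number beyond the scatter. They also leave open whether the ethoxy-for-chloro step would hold with 3-fluorobenzyl or 4-methylbenzyl present.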